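Triazole ether series: swapping the ring-nitrogen substituent

This account rests on a few compounds, and the source may have more. Where it says the series, first, only, none or still open, it means among the compounds named here.

All compounds share the core of compound 1 `CCOC(=O)C1=Cc2ccccc2OC1(OCc1cc(-c2ccc(F)cc2F)no1)C(F)(F)F`, an ethyl ester bearing a trifluoromethyl group and an ether-linked heterocycle. In a functional assay on HeLa cells (Homo sapiens) for inhibition, read by MTT assay, with a stated time of 24 h (on this read-out lower numbers stand for stronger inhibition and higher numbers for weaker inhibition), compound 1 reaches only a limit, > 150000 nM. Compound 3 `Cc1ccc(-c2cc(COC3(C(F)(F)F)Oc4ccccc4C=C3C(=O)O)on2)cc1`, the free acid with an isoxazole arm, gives 33400 nM. Compound 2 `CCOC(=O)C1=Cc2ccccc2OC1(OCc1cn(CC(=O)Nc2ccc(C)cc2)nn1)C(F)(F)F` gives 67400 nM; compound 2 and compound 3 sit within the scatter of one another, so no order between them is claimed. Compound 4 `CCOC(=O)C1=Cc2ccccc2OC1(OCc1cn(-c2ccccc2)nn1)C(F)(F)F` differs from compound 2 by phenyl in place of ((4-methylphenyl)carbamoyl)methyl on an aromatic nitrogen. With no measured step of this kind in the set, the expected step from compound 2 to compound 4 in this assay is a 1.1-fold lower number from compound 2 to compound 4 (0.05 log units; within the scatter), not beyond the scatter in either direction. Compound 4 is therefore estimated at 60000 nM, within 18000 nM to 150000 nM.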

Compound 4, half-maximal inhibitory concentration: > 150000 nM
Compound 4: only a limit was reported; the forecaster's own chance of this, stated with the estimate: 30%; at least 2.5-fold (0.39 log units) between middle value and limit.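

Phenyl in place of ((4-methylphenyl)carbamoyl)methyl on an aromatic nitrogen gives an at least 2.2-fold higher number from compound 2 to compound 4 (0.34 log units; beyond the scatter) in this assay, the first step in the set between compounds differing in one place. At this position, inhibition therefore depends on the substituent, with the ((4-methylphenyl)carbamoyl)methyl group the better of the two. The step has only a lower bound: the limit of > 150000 nM in this assay, at which 2 of the 4 values shown sit.

Which part of the ((4-methylphenyl)carbamoyl)methyl group matters remains open, whether the amide hydrogen, the carbonyl or the 4-methylphenyl ring. A benzyl group or a longer chain ending in an amine at this nitrogen would help separate these.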